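Acetyl on the ring nitrogen: a step expected, not measured

A few compounds are considered here, and "the series" means these few. Any claim that something is new, unique, unknown or untested is made for them only; others in the source may bear on it.

Compound 1 `Nc1cc(Cl)c2nc[nH]c2n1` is a small core carrying a free amino group. For the measured compounds named here, in a functional assay on KB cells (Homo sapiens) for cytotoxicity (a higher number here means that more compound is needed for the effect, a lower number that less compound is needed), compound 1 gives 1 ug/mL, the only plain number among the values shown. Compound 2 `Cc1ccc(S(=O)(=O)/N=c2\cc(Cl)c3ncn4c3n2C[C@H]2O[C@@H]4[C@@H]3OC(C)(C)O[C@@H]32)cc1` is a much larger derivative built on the same core. In this assay compound 2 gives > 22 ug/mL, which is a limit of the assay rather than a number (the limit of > 22 ug/mL in this assay, at which 1 of the 2 values shown sits). Compound 3 `CC(=O)Nc1cc(Cl)c2nc[nH]c2n1` differs from compound 1 in one place: acetyl in place of hydrogen on a nitrogen on an aromatic ring. Going by the values given here, no pair of measured compounds shows this kind of change, so its size can only be expected. The step from compound 1 to compound 3 is expected to be a 3.0-fold higher number from compound 1 to compound 3 (0.48 log units; beyond the scatter), a modest loss somewhat beyond the usual scatter. Compound 3 is therefore estimated at 3 ug/mL in this assay, with a likely range from 0.8 ug/mL to 12 ug/mL.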

Compound 3, concentration for half-maximal effect: > 22 ug/mL
Compound 3 gave a limit, no number; the forecaster's own chance of this, stated with the estimate: 10%; middle value at least 7.3-fold (0.86 log units) from the limit.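

For the compounds shown here, the change from amino to acetamido is the first single change that can be read at this nitrogen, since compound 1 and compound 2 differ in more than one place. In this assay it gives an at least 22-fold higher number from compound 1 to compound 3 (1.34 log units; beyond the scatter), so on this core even a small acetyl on the free amino group costs a large amount of cytotoxic effect. The reading for compound 3 is a limit of the assay and not a number, which places it with compound 2 at the end of the measurable range: the limit of > 22 ug/mL in this assay, at which 2 of the 3 values shown sit.

The compounds shown leave open whether any group on this nitrogen brings the same loss, or whether it is tied to the carbonyl of acetyl, as an ethyl group or a longer butyryl chain could show. They also leave open how much compound 3 would need for the half-maximal effect.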